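A few compounds are considered here, and "the series" means these few. Any claim that something is new, unique, unknown or untested is made for them only; others in the source may bear on it.

Of the compounds shown here, three have so far been tested in a functional assay on CEM-DNR-bulk cells (Homo sapiens), read by MTT assay, with a stated time of 72 h; on this read-out lower numbers stand for stronger inhibition and higher numbers for weaker inhibition. Compound 1 `CNc1ncnc2c1c(-c1ccccc1)cn2[C@@H]1O[C@H](CO)[C@@H](O)[C@H]1O` gives > 20000 nM, which is a limit of the assay rather than a number. Compound 2 `O=c1[nH]cnc2c1c(-c1cc3ccccc3o1)cn2[C@@H]1O[C@H](CO)[C@@H](O)[C@H]1O` likewise gives only a limit, > 20000 nM. Compound 3 `CNc1ncnc2c1c(-c1cc3ccccc3o1)cn2[C@@H]1O[C@H](CO)[C@@H](O)[C@H]1O` also reaches only a limit, > 20000 nM. The change from compound 3 to compound 1 is phenyl in place of 1-benzofuran-2-yl on an aromatic carbon, and the step that the two limits leave unreadable from compound 3 to compound 1 cannot be read because of the limit of > 20000 nM in this assay, at which 3 of the 3 values shown sit. The difference between the cores of compound 2 and compound 3 is not broken down here. Compound 4 `O=c1[nH]cnc2c1c(-c1ccccc1)cn2[C@@H]1O[C@H](CO)[C@@H](O)[C@H]1O` has not yet been measured; it differs from compound 2 by phenyl in place of 1-benzofuran-2-yl on an aromatic carbon, the same change at the same place. In this assay compound 4 is expected to show a step of a number no higher from compound 2 to compound 4 (the limit leaves the size open), resting only on the unreadable step that the two limits leave unreadable from compound 3 to compound 1. Compound 4 is therefore estimated at 20000 nM, most likely once more a limit.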

Compound 4, half-maximal inhibitory concentration: > 20000 nM
Compound 4: a limit, no number; the forecaster's own chance of this, stated with the estimate: 85%; the middle value sits exactly at the limit.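

No step can be read between compound 2 and compound 4, because both values are limits and not numbers: the limit of > 20000 nM in this assay, at which 4 of the 4 values shown sit. The compounds shown leave open whether phenyl and 1-benzofuran-2-yl differ at all in this assay.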